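Removing a Pyrrolidinyl Group and Cell Toxicity

The source may report more compounds than this note shows. Statements on the series, on what has been measured and on what is new or still open speak of the compounds shown alone.

Four compounds are compared here, built on two different cores. Compound 1 `Cn1c(-c2ccc(NC(=O)CN3CCCC3)cc2)nc2cc(C(F)(F)F)ccc21` and compound 2 `CC(=O)Nc1ccc(-c2nc3cc(C(F)(F)F)ccc3n2C)cc1` share the first core; compound 3 `O=C(CN1CCCC1)Nc1ccc(-c2nc3ccccc3[nH]2)cc1` and compound 4 `CC(=O)Nc1ccc(-c2nc3ccccc3[nH]2)cc1` share the second. The difference between the two cores is not broken down here.

In an ADME assay on MT4 cells (Homo sapiens) for cytotoxicity, read by MTT assay, with a stated time of 96 h (on this read-out higher numbers stand for lower toxicity in this test and lower numbers for higher toxicity in this test), compound 1 gives 16000 nM. Compound 2 gives 15000 nM in this assay. Compound 3 gives 40000 nM in this assay, the highest number among the three measured compounds, standing beyond the usual scatter from both compound 1 and compound 2, which means compound 3 is the least toxic of the three in this test.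

The change from compound 1 to compound 2 is hydrogen in place of pyrrolidin-1-yl on a saturated chain carbon bound to a carbonyl carbon. It made a 1.1-fold lower number from compound 1 to compound 2 (0.03 log units; within the scatter). The change from compound 3 to compound 4 is hydrogen in place of pyrrolidin-1-yl on a saturated chain carbon bound to a carbonyl carbon, the same change at the same place, now on the second core.

Because a 1.1-fold lower number from compound 1 to compound 2 (0.03 log units; within the scatter) was within the scatter, the step from compound 3 to compound 4 is expected to be similarly small, namely a 1.1-fold lower number from compound 3 to compound 4 (0.02 log units; within the scatter). Compound 4 is therefore estimated at 38000 nM in this assay. Within the data shown here, for compound 4 the estimate is expected to lie between 19000 nM and 80000 nM, the width reflecting that only one earlier example of this change is available, on a different core.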

Compound 4, half-maximal cytotoxic concentration: 100000 nM
Compound 4: the middle estimate sits 2.6-fold (0.42 log units) below what was measured, and the stated range ends below it.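

Taking away the pyrrolidin-1-yl group on the second core did not repeat what it did on the first: in this assay the change gave a 2.5-fold higher number from compound 3 to compound 4 (0.40 log units; beyond the scatter), and a higher number here stands for lower toxicity in this test. Set side by side, the two results differ, so the size of the step did not carry over from one core to the other: the same change on two cores in this assay, a 1.1-fold lower number (0.03 log units; within the scatter) from compound 1 to compound 2 and a 2.5-fold higher number (0.40 log units; beyond the scatter) from compound 3 to compound 4, 2.7-fold (0.43 log units) apart, beyond the scatter of two such steps. Among these compounds, this shows that the same change can have a different outcome on these two cores, but with only one pair of compounds on each core it does not show why the steps differ, nor how the change would behave on any further core.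

The compounds shown leave open whether another group on that saturated chain carbon, such as a piperidin-1-yl or morpholin-4-yl amine, a carboxylic acid or a longer chain, would follow the pattern of the first core or the second. Also open, on these data alone, is which difference between the two cores, the trifluoromethyl group or the methyl group, goes along with the split between the two steps.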